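A few compounds are considered here, and "the series" means these few. Any claim that something is new, unique, unknown or untested is made for them only; others in the source may bear on it.

Two thiosemicarbazones of this series have been run in a functional assay on B16 cells (Mus musculus) for inhibition, tested at 10 uM (on this read-out lower numbers stand for less inhibition and higher numbers for more inhibition at the one concentration tested (going by the name of the read-out)), so far: compound 1 `CC(C)(C)c1ccc(/C=N/NC(N)=S)cc1` and compound 2 `Cc1ccccc1/C=N/NC(N)=S`. In this assay compound 1 gives > 100%, which is a limit of the assay rather than a number. In this assay compound 2 likewise gives > 100%, again a limit of the assay and not a measured number. Thus compound 2 stands at the same limit as the only other value shown, and the limit of > 100% in this assay, at which 2 of the 2 values shown sit, is the whole of the evidence available; no measured step between compounds exists in this set.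

Compound 3 `CCc1ccccc1/C=N/NC(N)=S` is not yet measured. It differs from compound 2 by methyl in place of hydrogen on a saturated chain carbon bound to an aromatic carbon. On the basis of compound 2 sitting at the limit, no step beyond the scatter is expected in this assay; the step from compound 2 to compound 3 is estimated at a number no higher from compound 2 to compound 3 (the limit leaves the size open). For compound 3 the expected value in this assay is 100%, with a range from 85% to 100%, and most probably the result is again reported only as a limit.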

Compound 3, a percentage reported as inhibition, at one concentration (the size of the read-out at that concentration, not a potency): > 100%
Compound 3 gave a limit, no number (the forecaster's own chance of this, stated with the estimate: 75%); the middle value sits exactly at the limit.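

No step from compound 2 to compound 3 can be read in this assay, since both results are limits and not numbers: the limit of > 100% in this assay, at which 3 of the 3 values shown sit.

The compounds shown leave open how compound 1, compound 2 and compound 3 rank, and which change to the shared core would give a readable number.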